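The source may hold more compounds than are shown below. What is called first, only, known or untested is meant among the compounds shown, and "the series" means these compounds.

In an ADME assay on L02 cells (Homo sapiens) for inhibition, read by CCK-8 assay, with a stated time of 48 h (a lower number here means a stronger inhibitor of growth, a higher number a weaker inhibitor of growth), compound 1 (`Cc1ccccc1Nc1nc(Nc2cccnc2)ncc1Cl`) gives 22900 nM and compound 2 (`COc1ccc(CNc2nc(Nc3ccc(N4CCN(C)CC4)cn3)ncc2Cl)cc1`) gives 12900 nM, so the two numbers lie within the usual scatter of each other. Compound 3 (`CCc1ccc(Nc2nc(Nc3ccc(N4CCN(C)CC4)cn3)ncc2Cl)cc1`) differs from compound 2 at one place: 4-ethylphenyl in place of 4-methoxybenzyl on a nitrogen on an aromatic ring, with 4-ethylphenyl in place of 4-methoxybenzyl on a nitrogen on an aromatic ring. Among the compounds with values here, two values give little to go on, and no measured pair isolates this change. In this assay, the expected step, a 1.2-fold lower number from compound 2 to compound 3 (0.07 log units; within the scatter), stays within the scatter. The estimated value for compound 3 is 11000 nM, with an expected range of 4000 nM to 30000 nM.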

Compound 3, concentration for 50% growth inhibition: 12100 nM
Beside the measured number, compound 3's estimate is 1.1-fold (0.04 log units) below it, within the range that was stated.
By their numbers in this assay, from the lowest: compounds 3, 2 and 1 (each within the scatter of the next).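

In this assay, within the data shown here, the step at this nitrogen, a 1.1-fold lower number from compound 2 to compound 3 (0.03 log units; within the scatter), gives the first direct comparison at this position. It shows that 4-ethylphenyl can take the place of 4-methoxybenzyl, losing the oxygen and its hydrogen-bond acceptor, with no change in the number beyond the scatter. No supporting measurement is available to explain this result. Going by these compounds, what a group carrying an amine or a carboxylic acid would give on this nitrogen remains open. A single pair also cannot show whether this position tolerates other changes equally well.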